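The compounds below may be only part of what the source reports. "The series", "measured", "known", "first", "only" and "open" are said of these compounds alone.

Measured compounds in the series:
- compound 1, `Nc1cc(N)c2nc(-c3ccccc3)c(Oc3ccc(Cl)c(Cl)c3)nc2c1`, gives < 100000 nM in a functional assay on DU-145 cells (Homo sapiens) for inhibition, read by sulforhodamine B assay, with a stated time of 48 h; on this read-out higher numbers stand for lower toxicity in this test and lower numbers for higher toxicity in this test; this value is a limit of the assay and not a number.
- compound 2, `CCOC(=O)[C@H](CCC(=O)O)NC(=O)c1ccc(Sc2nc3cc(N)cc(N)c3nc2-c2ccccc2)cc1`, gives < 100000 nM in this assay; this value is a limit.
- compound 3, `COc1ccc(CNc2nc3cc(N)cc(N)c3nc2-c2ccccc2)cc1`, gives < 100000 nM in this assay; this value is a limit.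

Compound 1 therefore stands only at a limit, as do the other two values shown. Among the compounds with values here, no step between measured compounds is available, and the shared core carries, across the three, different groups on the position that varies. The whole picture rests on (the limit of < 100000 nM in this assay, at which 3 of the 3 values shown sit).

Compound 4, `Nc1cc(N)c2nc(-c3ccccc3)c(Oc3ccc(F)cc3)nc2c1`, is not yet measured. It differs from compound 1 by 4-fluorophenyl in place of 3,4-dichlorophenyl on an oxygen on an aromatic ring. With every measured value sitting at the limit, no direction for the change can be read from the data. The expectation for the step from compound 1 to compound 4 is therefore none beyond the scatter, written as a step that the limit leaves unreadable from compound 1 to compound 4, with the most likely outcome that compound 4 again reports only a limit. The estimate for compound 4 in this assay is 40000 nM, with a range from 5000 nM to 100000 nM.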

Compound 4, concentration lethal to 50% of the cells: < 100000 nM
Compound 4: no number, only a limit; the forecaster's own chance of this, stated with the estimate: 80%; the middle value does not contradict the limit.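

In this assay compound 4 gives < 100000 nM, a limit of the assay and not a number. No step can be read from compound 1 to compound 4, with 4-fluorophenyl in place of 3,4-dichlorophenyl, and the picture still rests on one limit: the limit of < 100000 nM in this assay, at which 4 of the 4 values shown sit. The compounds shown leave open how far any of them lies from that limit and whether the group on the oxygen changes the read-out in this assay.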